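Acetyl Ester of a Diterpenoid Acid: Expected Cytotoxicity

The compounds below may be only part of what the source reports. "The series", "measured", "known", "first", "only" and "open" are said of these compounds alone.

Compound 2 (`C=C1CC[C@@H]2[C@](C)(CCC[C@]2(C)C(=O)O)[C@H]1CC/C(C)=C/CO`) gives 72.9 ug/mL in a functional assay on HT-1080 cells (Homo sapiens) for cytotoxicity, read by MTT assay, with a stated time of 24 h (a higher number here means that more compound is needed for the effect, a lower number that less compound is needed), the higher of the two numbers in hand, though compound 1 (`CC(C)=CCc1cc(/C=C/C(=O)O)cc2c1OC(C)(C)C(O)C2`) at 71.5 ug/mL lies within the scatter of it. Compound 3 (`C=C1CC[C@@H]2[C@](C)(CCC[C@]2(C)C(=O)O)[C@H]1CC/C(C)=C/COC(C)=O`) differs from compound 2 by acetyl in place of hydrogen on an oxygen on a saturated carbon. Within the data shown here, no measured pair shows this change, so the expectation rests on compound 2 alone, and the step from compound 2 to compound 3 is estimated at a 1.1-fold lower number from compound 2 to compound 3 (0.05 log units; within the scatter), not beyond the scatter. Compound 3 is therefore expected to give 65 ug/mL in this assay, in a range from 30 ug/mL to 140 ug/mL.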

Compound 3, concentration for half-maximal effect: 70.1 ug/mL
Compound 3: middle estimate off by 1.1-fold (0.03 log units), on the low side; the range from low to high includes it.
By their numbers in this assay, from the lowest: compounds 3, 1 and 2 (each within the scatter of the next).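

Compound 3 carries acetoxy where compound 2 carries hydroxy, the first direct test of this oxygen, and the change gives a 1.0-fold lower number from compound 2 to compound 3 (0.02 log units; within the scatter) in this assay. At this position, capping the hydroxy with acetyl leaves the two compounds indistinguishable in this assay, so the free hydrogen on this oxygen is not needed to keep the reading. No measured evidence bears on why this is so. The compounds shown leave open whether a longer acyl chain, such as butanoyl, or a benzoyl group on this oxygen would read the same. They also leave open whether an amine in place of this oxygen would.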